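Swapping a Hydroxy for a Sulfamoyl on the Shared Core

The compounds below may be only part of what the source reports. "The series", "measured", "known", "first", "only" and "open" are said of these compounds alone.

Compound 1, `CC(C)(C)CCOc1cccc(O)c1C(=O)/C=C/c1ccc(C(=O)O)cc1`, gives 8450 nM in a functional assay on ACHN cells (Homo sapiens) for antiproliferative activity, read by sulforhodamine B assay; a higher number here means a weaker inhibitor of growth, a lower number a stronger inhibitor of growth.
Compound 2, `CC(C)(C)CCOc1cccc(O)c1C(=O)/C=C/c1ccc(O)cc1`, gives 3140 nM in this assay.
Compound 3, `O=C(/C=C/c1ccc(O)cc1)c1c(O)cccc1OCC1CCCC1`, gives 3510 nM in this assay.

Compound 2 has the lowest number of the three. Compound 3 sits nearest, a 1.1-fold higher number from compound 2 to compound 3 (0.05 log units; within the scatter), a gap within the scatter, so the two cannot be ranked against each other. Compound 1 sits furthest, and the step of a 2.7-fold lower number from compound 1 to compound 2 (0.43 log units; beyond the scatter) lies beyond the scatter.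

Compound 4, `CC(C)(C)CCOc1cccc(O)c1C(=O)/C=C/c1ccc(S(N)(=O)=O)cc1`, is not yet measured. It differs from compound 2 in one place: sulfamoyl in place of hydroxy on an aromatic carbon. Within the data shown here, the only measured step at this same position is a 2.7-fold lower number from compound 1 to compound 2 (0.43 log units; beyond the scatter), where a carboxy gave way to a hydroxy. The step of a 1.1-fold higher number from compound 2 to compound 3 (0.05 log units; within the scatter) concerns the other end of the shared core and says nothing about this change. Among the measured compounds shown here, no measured compound carries a sulfamoyl, so the direction rests on that one step alone.

The expectation is a modest move to a higher number, a 1.6-fold higher number from compound 2 to compound 4 (0.20 log units; within the scatter), since a hydroxy was the better of the two groups tried there in a 2.7-fold lower number from compound 1 to compound 2 (0.43 log units; beyond the scatter). Compound 4 is therefore estimated at 5000 nM, with a likely range from 2000 nM to 13000 nM.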

Compound 4, concentration for 50% growth inhibition: 3300 nM
Compound 4: middle estimate off by 1.5-fold (0.18 log units), on the high side, and the stated range covers the measured number.
By their numbers in this assay, from the lowest: compounds 2, 4 and 3 (each within the scatter of the next); then compound 1.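

In this assay, the larger sulfamoyl group can stand in for hydroxy at this position with no readable change, as a 1.1-fold higher number from compound 2 to compound 4 (0.02 log units; within the scatter) shows, so compound 2 and compound 4 cannot be ranked. The position therefore accepts more than one group, and carboxy is the one that stands apart among the three tried here, with a 2.6-fold lower number from compound 1 to compound 4 (0.41 log units; beyond the scatter) adding a second step beyond the scatter alongside a 2.7-fold lower number from compound 1 to compound 2 (0.43 log units; beyond the scatter). Nothing measured explains why the carboxy compound separates from the other two.

On these data alone, how an amine or a methoxy group would read at this position remains open. It is also unknown whether sulfamoyl would give a similar reading when paired with the cyclopentyl chain of compound 3.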